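Bromophenyl sulfonyl replaces pentafluorophenyl on the shared core

A few compounds are considered here, and "the series" means these few. Any claim that something is new, unique, unknown or untested is made for them only; others in the source may bear on it.

Compound 1 `COc1ccc(-c2cc(=O)c3c(OC)cc(OC)cc3n2C)cc1`: "not determined" (no result reported) in a functional assay on HepG2 cells (Homo sapiens) for antiproliferative activity, with a stated time of 72 h; a lower number here means that less compound is needed, a higher number that more compound is needed for the effect
Compound 2 `COc1ccc(-c2cc(=O)c3c(OC)cc(OC)cc3n2S(=O)(=O)c2ccc(F)cc2)cc1`: > 65500 nM, a limit of this assay
Compound 3 `COc1ccc(-c2cc(=O)c3c(OC)cc(OC)cc3n2S(=O)(=O)c2c(F)c(F)c(F)c(F)c2F)cc1`: > 34400 nM, a limit of this assay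

Compound 3 stands at a limit in this assay, so its value is not a number but the edge of what the assay could report (the limit of > 34400 nM in this assay, at which 1 of the 3 values shown sits). Compound 2 likewise sits at a limit (the limit of > 65500 nM in this assay, at which 1 of the 3 values shown sits). For the measured compounds named here, the only step between measured compounds, a step that the two limits leave unreadable from compound 2 to compound 3, is therefore unreadable in size and direction. Compound 4 `COc1ccc(-c2cc(=O)c3c(OC)cc(OC)cc3n2S(=O)(=O)c2ccc(Br)cc2)cc1` differs from compound 3 by 4-bromophenyl in place of 2,3,4,5,6-pentafluorophenyl on a sulfonyl sulfur. Going by the values given here, that step is the only one bearing on compound 4, and it gives no readable size, so no direction beyond the scatter is expected; compound 4 is expected to stay at a limit as well. The estimated step that the limit leaves unreadable from compound 3 to compound 4 carries this expectation. For compound 4 the expected value is 50000 nM, within 10000 nM to 200000 nM.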

Compound 4, half-maximal effective concentration: 16300 nM
For compound 4 the middle estimate is 3.1-fold (0.49 log units) above the measured one; measured number inside the range.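

Compound 4 is the first compound shown to give a number rather than a limit in this assay. Placing 4-bromophenyl on the sulfonyl sulfur gives an at least 2.1-fold lower number from compound 3 to compound 4 (0.32 log units; beyond the scatter), while bromo in place of fluoro on an aromatic carbon gives an at least 4.0-fold lower number from compound 2 to compound 4 (0.60 log units; beyond the scatter). Each step starts from a limit and so gives only a minimum size, but both show that the aryl group on this sulfur can move the result beyond the scatter.

From the compounds shown here alone, it remains open whether bromo is special here. A 4-chlorophenyl or 4-aminophenyl group on the same sulfur could show how far this trend extends.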